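A Fluorine Takes the Place of a Methyl

The source may report more compounds than this note shows. Statements on the series, on what has been measured and on what is new or still open speak of the compounds shown alone.

Compound 2: `COc1cc2c(Oc3ccc(NC(=O)c4cn(-c5ccccc5)nn4)cc3F)ccnc2cc1OCCCN1CCCCC1` — 100 nM
Compound 3: `COc1cc2c(Oc3ccc(NC(=O)c4cn(-c5ccccc5C)nn4)cc3F)ccnc2cc1OCCCN1CCCCC1` — 3250 nM
Compound 1: `COc1cc2c(Oc3ccc(NC(=O)c4cn(-c5ccccc5C)nn4)cc3F)ccnc2cc1OCCCN1CCCC1` — "not determined" (no result reported)

All three compounds share the same core and differ only at the phenyl ring attached to the triazole and at the cyclic amine at the end of the ether chain. In a functional assay on MKN-45 cells (Homo sapiens) for cytotoxicity, read by MTT assay, with a stated time of 72 h (on this read-out higher numbers stand for weaker inhibition and lower numbers for stronger inhibition), compound 2 gives 100 nM. In this assay compound 3 gives 3250 nM, which is the highest of the two numbers reported. For compound 1 this assay gives "not determined" (no result reported). Among the compounds with values here, the only measured step between neighbours is a 33-fold higher number from compound 2 to compound 3 (1.51 log units; beyond the scatter), a change of methyl in place of hydrogen on an aromatic carbon.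

Compound 4 `COc1cc2c(Oc3ccc(NC(=O)c4cn(-c5ccccc5F)nn4)cc3F)ccnc2cc1OCCCN1CCCCC1` has not yet been measured. It differs from compound 3 by fluoro in place of methyl on an aromatic carbon. Within the data shown here, no measured compound carries this fluoro, so only the step from compound 2 to compound 3 bears on it, and that step was large. Compound 4 is therefore expected to lie somewhere between the two measured neighbours, with a 5.4-fold lower number from compound 3 to compound 4 (0.73 log units; beyond the scatter) as the expected step. The estimate for compound 4 is 600 nM, with a range from 120 nM to 3000 nM.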

Compound 4, half-maximal inhibitory concentration: 1290 nM
Estimate against measurement, compound 4: 2.2-fold (0.33 log units) below; the range from low to high includes it.
By their numbers in this assay, from the lowest: compound 2; then compound 4; then compound 3.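

In this assay, the swap of 2-methylphenyl to 2-fluorophenyl gives a 2.5-fold lower number from compound 3 to compound 4 (0.40 log units; beyond the scatter) and so shows that this position responds to which group sits on it, and not only to whether its hydrogen has been replaced, since methyl and fluoro each add a single heavy atom yet give different numbers. The fluoro recovers only part of what the methyl lost, as the comparison with the parent phenyl gives a 13-fold higher number from compound 2 to compound 4 (1.11 log units; beyond the scatter) and leaves both groups on this carbon, ortho to a large group, with higher numbers than hydrogen, so that compound 2 keeps the lowest number of the three. Nothing shown here measures why these groups differ or why either one gives a higher number than hydrogen.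

The compounds shown leave open how a chlorine atom, a methoxy group or an amine would read at this same carbon, and whether a fluoro on another carbon of the phenyl ring would follow the same trend. With no number for compound 1, the effect of exchanging the cyclic amine at the end of the ether chain also cannot be read.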